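The source may hold more compounds than are shown below. What is called first, only, known or untested is meant among the compounds shown, and "the series" means these compounds.

Of the compounds shown here, three built on a shared core have been measured in a functional assay on BXPC-3 cells (Homo sapiens) for cytotoxicity, read by MTT assay, with a stated time of 72 h; a higher number here means a weaker inhibitor, a lower number a stronger inhibitor. Compound 1 `COc1cc(NC2=CC(=O)c3ncncc3C2=O)cc(OC)c1` gives 16300 nM in this assay. Compound 2 `COc1ccc(-c2ccc(NC3=CC(=O)c4ncncc4C3=O)cc2)cc1` gives 3500 nM in this assay, the lowest of the two numbers recorded, and compound 1 sits a clear step higher, beyond the usual scatter. Compound 3 `O=C1C(Nc2cccc(B(O)O)c2)=CC(=O)c2ncncc21` is reported in this assay only as a limit, > 10000 nM, so no number is known for it (the limit of > 10000 nM in this assay, at which 1 of the 3 values shown sits).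

Compound 4 `O=C1C(Nc2ccc(Oc3ccccc3)cc2)=CC(=O)c2ncncc21` has not yet been measured. It differs from compound 2 in one place: phenoxy in place of 4-methoxyphenyl on an aromatic carbon. Among the compounds with values here, no measured pair differs in just this way, so the size of the step has to be guessed. The step from compound 2 to compound 4 is expected to be small, roughly within the scatter or a little beyond it, and is estimated as a 1.6-fold higher number from compound 2 to compound 4 (0.20 log units; within the scatter), leaning toward a weaker inhibitor. Compound 4 is therefore expected to give about 5500 nM in this assay, with a plausible range from 1800 nM to 17000 nM, and a modest chance that only a limit is reported.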

Compound 4, half-maximal inhibitory concentration: 3600 nM
Compound 4: the middle estimate sits 1.5-fold (0.18 log units) above what was measured; low and high end bracket the measured number.
By their numbers in this assay, from the lowest: compounds 2 and 4 (each within the scatter of the next); then compound 1.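

Within the data shown here, putting phenoxy in place of 4-methoxyphenyl on this aromatic carbon, para to a large group, gives a 1.0-fold higher number from compound 2 to compound 4 (0.01 log units; within the scatter) in this assay, and this is the first step between two measured compounds that differ in one place. It shows that the read-out does not separate these two groups at this position, even though they are built differently, with one carrying an extra heavy atom and the other linking its ring through oxygen. No measured property among the data shown bears on this result, and it stays an observation without an explanation.

Going by these compounds, whether other groups on this carbon would also leave the number unchanged stays open, for instance a carboxylic acid, an amine such as morpholine, or a longer alkyl chain. On these data alone, it also stays open how much the large group itself contributes, since compound 1 and compound 3 differ from compound 2 and compound 4 in more than one place, and the same swap on another core would be a separate question.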